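The source may report more compounds than this note shows. Statements on the series, on what has been measured and on what is new or still open speak of the compounds shown alone.

Measured compounds in an assay on isolated protein for inhibition of DNA topoisomerase 1 (Homo sapiens), with a stated time of 30 min, tested at 100 uM; a higher number here means a stronger effect of the compound at the concentration tested, a lower number a weaker effect:
compound 1 `Oc1cccc(-c2cc(-c3ccncc3)nc(-c3cccc(Cl)c3)c2)c1` gives 0%
compound 2 `Oc1cccc(-c2cc(-c3cccc(Cl)c3)nc(-c3ccco3)c2)c1` gives 5.5%
compound 3 `Oc1cccc(-c2cc(-c3ccccc3)nc(-c3cccc(Cl)c3)c2)c1` gives 11.5%

Compound 1 stands lowest of the three numbers in this assay; compound 2 is its nearest neighbour, compound 3 the furthest. The two steps away from compound 1 are a number 5.5 percentage points higher from compound 1 to compound 2 (within the scatter) and a number 11.5 percentage points higher from compound 1 to compound 3 (beyond the scatter); between the other two compounds the step is a number 6 percentage points higher from compound 2 to compound 3 (within the scatter). All three steps exchange the aryl group that is not the chlorophenyl ring; none of them moves the chlorine on that ring.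

Compound 4 `Oc1cccc(-c2cc(-c3ccncc3)nc(-c3ccccc3Cl)c2)c1` has not yet been measured in this assay. It differs from compound 1 only in the chlorophenyl ring: 2-chlorophenyl in place of 3-chlorophenyl on an aromatic carbon. Going by the values given here, no measured step bears directly on this change. Among the compounds with values here, what the series does show is that every number so far is small and that even the largest step among them is modest, so in this assay compound 4 is expected to stay near compound 1, with no step beyond the scatter in either direction. The expected step is a number 3 percentage points higher from compound 1 to compound 4 (within the scatter). Compound 4 is estimated at 3%, with a range of 0% to 14%.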

Compound 4, a percentage reported as inhibition, at one concentration (the size of the read-out at that concentration, not a potency): 0%
Compound 4: the middle estimate sits 3 percentage points above what was measured; measured number inside the range.
By their numbers in this assay, from the lowest: compounds 1, 4, 2 and 3 (each within the scatter of the next, the first and the last beyond it).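

In this assay, going by these compounds alone, the first change at the chlorophenyl ring, on the aromatic carbon next to the ring nitrogen, gives no change at the digits printed from compound 1 to compound 4 (within the scatter) when 2-chlorophenyl replaces 3-chlorophenyl with pyridin-4-yl kept in the other aryl position. With compound 4 at 0% as well, the pair sits at the bottom of the read-out, where this exchange of chlorine position raises the number no further and any loss could not be seen. No evidence is available that accounts for this result.

2-Chlorophenyl appears here only alongside pyridin-4-yl, so its effect remains open in the phenyl setting, where compound 3 gives 11.5% and there is room to register a drop. Also open, as far as these compounds go, is whether a carboxylic acid or an aminomethyl group in place of the chlorine would lift the number off zero.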